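The compounds below may be only part of what the source reports. "The series", "measured", "known", "first", "only" and "open" are said of these compounds alone.

Compound 2 `Fc1ccccc1NC(=S)N/N=C/c1ccc2ccccc2n1` reaches no measurable number in a functional assay on HT-29 cells (Homo sapiens) for antiproliferative activity, read by sulforhodamine B assay, with a stated time of 72 h; a lower number here means a stronger inhibitor, a higher number a weaker inhibitor: compound 2 returns only a limit of the assay, > 100000 nM. Compound 3 `NC(=S)N/N=C/c1cnc2ccccc2n1` likewise gives only a limit in this assay, > 100000 nM. Within the data shown here, compound 1 `CN(C)C(=S)N/N=C/c1cnc2ccccc2n1` is the one compound with a number, giving 450 nM in this assay, and the single measured step, an at least 220-fold higher number from compound 1 to compound 3 (2.34 log units; beyond the scatter), shows how far a change on the thiocarbonyl carbon can move the result; it shares with compound 2 the pattern of the limit of > 100000 nM in this assay, at which 2 of the 3 values shown sit.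

Compound 4 `Fc1ccc(NC(=S)N/N=C/c2ccc3ccccc3n2)cc1` differs from compound 2 by 4-fluorophenyl in place of 2-fluorophenyl on an amide-type nitrogen. Among the measured compounds shown here, no measured step touches the fluorophenyl group, so the one step recorded here does not bear on this change; it concerns a different part of the molecule. For the measured compounds named here, with compound 2 at a limit and no related step to lean on, compound 4 is expected to stay near that limit, so the change a number no higher from compound 2 to compound 4 (the limit leaves the size open) is estimated as none beyond the scatter. Compound 4 is therefore estimated at 100000 nM in this assay, with a range from 20000 nM to 300000 nM.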

Compound 4, half-maximal inhibitory concentration: 28500 nM
Estimate against measurement, compound 4: 3.5-fold (0.55 log units) above; the measured number falls inside the stated range.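

In this assay, the fluorophenyl group on the amide-type nitrogen is now shown to affect the result: 4-fluorophenyl in place of 2-fluorophenyl gives an at least 3.5-fold lower number from compound 2 to compound 4 (0.54 log units; beyond the scatter). The two compounds have the same atoms, so the earlier change on the thiocarbonyl carbon is no longer the only place where a single alteration is seen to move the number. The step can be read only as a lower bound because compound 2 is a limit of the assay: the limit of > 100000 nM in this assay, at which 2 of the 4 values shown sit.

Going by these compounds, it remains open whether a plain phenyl, chlorophenyl or methoxyphenyl group on this nitrogen would go further in this assay. On these data alone, it is also open whether the 4-fluorophenyl group would have any comparable effect on the core of compound 1.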